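Bis-aminomethylbenzene series: pyrimidine replacement, expected response

A few compounds are considered here, and "the series" means these few. Any claim that something is new, unique, unknown or untested is made for them only; others in the source may bear on it.

Measured so far:
compound 1, `Fc1cnc(NCc2ccc(CNc3ncc(F)cn3)cc2)nc1`: 75%
compound 2, `Clc1nc(Cl)nc(NCc2ccc(CNc3nc(Cl)nc(Cl)n3)cc2)n1`: 61%

Two compounds share the core and have numbers in a functional assay on MDA-MB-231 cells for antagonist activity at C-X-C chemokine receptor type 4 (Homo sapiens), tested at 10 nM; on this read-out lower numbers stand for a weaker effect and higher numbers for a stronger effect at the one concentration tested. Compound 1 gives 75%, the higher of the two, and compound 2 gives 61%; the gap between them lies beyond the scatter, but the two differ in more than one place, so nothing is drawn from it about any single change.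

Compound 3, `CSc1ccnc(NCc2ccc(CNc3ncc(F)cn3)cc2)n1`, is not yet measured. It differs from compound 1 by 4-(methylsulfanyl)pyrimidin-2-yl in place of 5-fluoropyrimidin-2-yl on an amine nitrogen. For the measured compounds named here, no measured pair isolates this kind of change, so the expected step rests on compound 1 alone.

A small step is expected, downward if anything, from compound 1 to compound 3 of a number 10 percentage points lower from compound 1 to compound 3 (within the scatter), not clearly beyond the scatter. Compound 3 is estimated at 65%, with a range from 40% to 85%.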

Compound 3, a percentage reported as inhibition, at one concentration (the size of the read-out at that concentration, not a potency): 62%
For compound 3 the middle estimate is 3 percentage points above the measured one, and the stated range covers the measured number.
By their numbers in this assay, from the lowest: compounds 2 and 3 (each within the scatter of the next); then compound 1.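

In this assay, for the compounds shown here, the first comparison that isolates one place reads a number 13 percentage points lower from compound 1 to compound 3 (beyond the scatter), with 4-(methylsulfanyl)pyrimidin-2-yl in place of 5-fluoropyrimidin-2-yl on an amine nitrogen. The read-out at this place therefore responds to the choice of group, though the step is modest and compound 3 still gives 62% at the one concentration tested. No available data bear on the reason for this step.

Going by these compounds, whether the step follows from losing the fluorine or from bringing in the methylsulfanyl group stays open, as this single replacement does both at once. On these data alone, the response to a methoxy group or an amine in place of the methylsulfanyl group also remains open.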